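Thiosemicarbazide series: aryl amide in place of aryloxyacetyl

A few compounds are considered here, and "the series" means these few. Any claim that something is new, unique, unknown or untested is made for them only; others in the source may bear on it.

Compound 1 `O=C(COc1ccccc1Cl)NNC(=S)NCc1ccc(-c2ccccc2)cc1` in an assay on isolated protein for inhibition of A disintegrin and metalloproteinase with thrombospondin motifs 5 (Homo sapiens), read by spectrophotometry, with stated times of 10 min and 3 h (a higher number here means a weaker inhibitor, a lower number a stronger inhibitor), gives 1900 nM, the lower of the two numbers recorded so far. Compound 2 `CC(C)(Oc1ccc(Cl)cc1)C(=O)NNC(=S)NCc1ccc(-c2ccccc2)cc1` in this assay gives 6900 nM, a gap that lies beyond the scatter. Compound 3 `O=C(NNC(=S)NCc1ccc(-c2ccccc2)cc1)c1ccc(Cl)cc1` has not been measured; it differs from compound 1 by 4-chlorophenyl in place of (2-chlorophenoxy)methyl on a carbonyl carbon, so the oxygen linker is absent and the aromatic ring sits directly on the carbonyl. For the measured compounds named here, no comparable step exists among the measured pair, so the expected step from compound 1 to compound 3 is a 1.5-fold higher number from compound 1 to compound 3 (0.17 log units; within the scatter), a small loss not clearly beyond the scatter. Compound 3 is estimated at 2800 nM, within 900 nM to 9000 nM.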

Compound 3, half-maximal inhibitory concentration: 700 nM
Estimate against measurement, compound 3: 4.0-fold (0.60 log units) above, outside the stated range (below it).
By their numbers in this assay, from the lowest: compound 3; then compound 1; then compound 2.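

In this assay the step on this carbonyl carbon, 4-chlorophenyl in place of (2-chlorophenoxy)methyl, is a gain (a 2.7-fold lower number from compound 1 to compound 3 (0.43 log units; beyond the scatter)), so the oxygen linker is not required for inhibition here. The whole group changes in this one step, so loss of the linker and the change from 2-chloro to 4-chloro cannot be separated. No supporting measurement explains the gain.

From the compounds shown here alone, whether the chlorine itself matters remains open. Also open, going by these compounds, is how a pyridine ring or a cyclohexyl group on the same carbonyl carbon would compare.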